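The compounds below may be only part of what the source reports. "The series", "measured", "known", "first", "only" and "open" are said of these compounds alone.

The study concerns metabolic stability in an ADME assay on microsomes from liver (Homo sapiens) for metabolic stability; a lower number here means that less of the compound is left, a higher number that more of the compound is left. Compound 1 `CCCCCOC(=O)N1CCN(C(=O)[C@H](CCC(=O)O)NC(=O)c2cc(N3CCC(C(=O)N(CC)CC)CC3)nc(-c3ccccc3)n2)CC1` has been measured in this assay, and so has compound 2 `CCCCCOC(=O)N1CCN(C(=O)[C@H](CCC(=O)O)NC(=O)c2nc(-c3ccccc3)cc(N3CCC(CN)CC3)n2)CC1`. In this assay compound 1 gives > 80%, which is a limit of the assay and not a number. Compound 2 in turn gives > 80% in this assay, again a limit rather than a number. Among the measured compounds shown here, compound 2 thus stands at the limit of > 80% in this assay, at which 2 of the 2 values shown sit; no step between measured compounds can be told, and the two values show only that neither falls short of that limit.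

Compound 3 `CCCCCOC(=O)N1CCN(C(=O)[C@H](CCC(=O)O)NC(=O)c2nc(-c3ccccc3)cc(N3CCC(COC)CC3)n2)CC1` has not yet been measured. It differs from compound 2 in one place: methoxy in place of amino on a saturated chain carbon bound to a saturated ring carbon. With both measured values sitting at the limit, the step expected in this assay from compound 2 to compound 3 is none beyond the usual scatter, which is an expected step that the limit leaves unreadable from compound 2 to compound 3. Compound 3 is therefore expected to remain at or near the limit, with an estimate of 85%, between 70% and 97%.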

Compound 3, percent of the compound remaining: > 80%
Compound 3 gave a limit, no number; the forecaster's own chance of this, stated with the estimate: 70%; the middle value does not contradict the limit.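

Compound 2 and compound 3 both give a limit and not a number, so no step between them can be read: the limit of > 80% in this assay, at which 3 of the 3 values shown sit.

The compounds shown leave open whether methoxy in place of amino changes the percent of compound remaining at all, and which change in the shared core, if any, would bring a value within readable range.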